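Replacing the acyl group of compound 3

The source may hold more compounds than are shown below. What is called first, only, known or untested is meant among the compounds shown, and "the series" means these compounds.

In a functional assay on VCaP cells (Homo sapiens) for antiproliferative activity, read by CCK-8 assay, with a stated time of 6 days (a higher number here means a weaker inhibitor, a lower number a stronger inhibitor), compound 3 `COC(=O)/C=C/C(=O)N[C@@H](C)Cn1ccc(-c2ccc(C#N)c(Cl)c2)n1` gives 5230 nM, the weakest of the three measured compounds. Compound 1 `CC(O)c1cccc(C(=O)N[C@@H](C)Cn2ccc(-c3ccc(C#N)c(Cl)c3)n2)c1` gives 900 nM and compound 2 `CC(=O)c1ccc(C(=O)N[C@@H](C)Cn2ccc(-c3ccc(C#N)c(Cl)c3)n2)cc1` gives 1400 nM, and the step between them is a 1.6-fold higher number from compound 1 to compound 2 (0.19 log units; within the scatter).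

Compound 4 `C[C@@H](Cn1ccc(-c2ccc(C#N)c(Cl)c2)n1)NS(=O)(=O)c1cn(C)cn1` has not yet been measured. It carries (1-methyl-1H-imidazol-4-yl)sulfonyl in place of (2-(methoxycarbonyl)ethenyl)carbonyl on an amine nitrogen.

Among the compounds with values here, two measured steps bear on this change, though neither involves a sulfonyl group. They are a 5.8-fold higher number from compound 1 to compound 3 (0.76 log units; beyond the scatter) and a 3.7-fold higher number from compound 2 to compound 3 (0.57 log units; beyond the scatter), both modest. In each, a group with a phenyl ring gives way to the open-chain group of compound 3. Compound 4 reverses that loss of a ring, but its ring is a different one on a different link, so only part of the gain is likely to carry over.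

The expected step is small, toward a lower number: a 1.7-fold lower number from compound 3 to compound 4 (0.24 log units; within the scatter). The estimated value for compound 4 is 3000 nM, with an expected range of 900 nM to 10000 nM.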

Compound 4, half-maximal inhibitory concentration: 13600 nM
Estimate against measurement, compound 4: 4.5-fold (0.66 log units) below, and the stated range ends below it.
By their numbers in this assay, from the lowest: compounds 1 and 2 (each within the scatter of the next); then compound 3; then compound 4.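

In this assay, this change at the amine nitrogen gives a 2.6-fold higher number from compound 3 to compound 4 (0.42 log units; beyond the scatter), so the open-chain group of compound 3 is not the least favourable group at this position among those shown. The incoming group does carry a ring, a five-membered aromatic ring with 2 hetero atoms, yet compound 4 does not return to the lower printed values of compound 1 and compound 2, so having a ring here is not enough on its own to give a lower number. No measurement shown here explains the rise.

Compound 4 changes both the link, from carbonyl to sulfonyl, and the group it carries, so the two effects cannot be separated. A 1-methyl-1H-imidazol-4-yl group on a carbonyl, or a phenyl group on a sulfonyl, would be needed to tell them apart.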